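The compounds below may be only part of what the source reports. "The series", "measured", "known", "first", "only" and "open" are said of these compounds alone.

Compound 1 `C[C@H](Oc1cc2cc(F)ccc2nc1N)c1cc2c(cnn2CC(=O)O)cc1-n1cccn1`: 0.5
Compound 2 `C[C@H](Oc1cc2cc(C(N)=O)ccc2nc1N)c1ncc(F)cc1-n1cccn1`: 1.9
Compound 3 `C[C@H](Oc1cc2cc(F)ccc2nc1N)c1cc(F)c(F)cc1-n1cccn1`: 4.1

Of the compounds shown here, three have been measured in a physicochemical assay for lipophilicity, using the shake flask method; on this read-out lower numbers stand for lower lipophilicity and higher numbers for higher lipophilicity. Compound 1 stands lowest of the three: compound 2 lies well above it, and compound 3 lies further above still, both gaps beyond the scatter. Within the data shown here, no two of the measured compounds differ in only one place, so no single step between them can be read directly.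

Compound 4 `C[C@H](Oc1cc2cc(F)ccc2nc1N)c1cc2c(cnn2CCO)cc1-n1cccn1` has not yet been measured. It differs from compound 1 in one place: hydroxymethyl in place of carboxy on a saturated chain carbon bound to an aromatic nitrogen. Among the measured compounds shown here, since no measured pair shows this change, its size must be estimated. Compound 3 shares the core of compound 1 and carries no carboxy. A sizeable upward step is expected, because compound 3 gives 4.1. Compound 4 is therefore estimated to reach 2.7 in this assay, within a range from 2 to 3.4. That estimate means a step of a number 2.20 log units higher from compound 1 to compound 4 (beyond the scatter), well beyond the scatter.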

Compound 4, distribution coefficient: 3.3
Beside the measured number, compound 4's estimate is 0.60 log units below it; the measured number falls inside the stated range.
By their numbers in this assay, from the lowest: compound 1; then compound 2; then compound 4; then compound 3.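

In this assay, among these compounds, exchanging carboxy for hydroxymethyl on a saturated chain carbon bound to an aromatic nitrogen gives a number 2.80 log units higher from compound 1 to compound 4 (beyond the scatter), the first reading of a single change. It shows that this one place alone can move the read-out by a large amount while the rest of the structure stays fixed. The step comes with one heavy atom fewer and with the same counts of hydrogen-bond donors and acceptors on both sides, and nothing available accounts for its size.

Left open is where other groups at this place would fall, such as an amine, a methyl ether or a longer chain ending in hydroxyl. Also open is whether the same exchange gives a step of similar size on another core, as this pair is the only one shown that carries it.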